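Swapping the aryl group on the carbonyl of compound 2

This account rests on a few compounds, and the source may have more. Where it says the series, first, only, none or still open, it means among the compounds named here.

Measured so far:
compound 1 `COc1cc(-c2cc(/C=C/C(=O)c3ccc(N)cc3)[nH]n2)cc(OC)c1OC`: -77%
compound 2 `COc1cc(-c2cc(/C=C/C(=O)c3ccc(Cl)c(Cl)c3)[nH]n2)cc(OC)c1OC`: 2%

In a functional assay on MDA-MB-231 cells (Homo sapiens) for cytotoxicity, read by sulforhodamine B assay, with a stated time of 48 h, tested at 100 uM (a lower number here means a stronger effect, a higher number a weaker effect of the compound at the concentration tested), compound 2 gives 2%, the highest of the two numbers; the nearest is compound 1 with -77%, a number well beyond the scatter below it.

Compound 3 `COc1ccc(C(=O)/C=C/c2cc(-c3cc(OC)c(OC)c(OC)c3)n[nH]2)cc1OC` has not been measured. It differs from compound 2 in one place: 3,4-dimethoxyphenyl in place of 3,4-dichlorophenyl on a carbonyl carbon.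

Among the measured compounds shown here, only one measured step exists, a number 79 percentage points higher from compound 1 to compound 2 (beyond the scatter), and it concerns a different group entering the same place, so it bears on the new change only loosely. It shows that the group on this carbonyl carbon can move the read-out a great deal, and that the 3,4-dichlorophenyl of compound 2 gives the weakest effect seen.

Because of a number 79 percentage points higher from compound 1 to compound 2 (beyond the scatter), a change away from 3,4-dichlorophenyl in compound 3 is expected to move the number downward, though by an uncertain amount: the estimated step is a number 27 percentage points lower from compound 2 to compound 3 (beyond the scatter), and compound 3 is expected to give about -25%, within a range from -75% to 25%.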

Compound 3, a percentage reported as activity, at one concentration (the size of the read-out at that concentration, not a potency): -84%
The estimate for compound 3 lay 59 percentage points above the measured number; measured number below the stated range.
By their numbers in this assay, from the lowest: compounds 3 and 1 (each within the scatter of the next); then compound 2.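

Putting 3,4-dimethoxyphenyl in place of 3,4-dichlorophenyl on the carbonyl carbon gives a number 86 percentage points lower from compound 2 to compound 3 (beyond the scatter) in this assay and shows that a strong effect at this position does not depend on the 4-aminophenyl group of compound 1. A second, differently substituted aryl group also reaches that level, since the change gives a number 7 percentage points lower from compound 1 to compound 3 (within the scatter) and leaves the two compounds indistinguishable in this measurement. Among these three compounds, 3,4-dichlorophenyl is therefore the group that stands apart, while the 4-aminophenyl and 3,4-dimethoxyphenyl groups cannot be separated.

The compounds shown leave open how an unsubstituted phenyl, a pyridine ring or a phenyl carrying a carboxylic acid would behave at this carbonyl carbon. Nothing available here explains the gap between 3,4-dichlorophenyl and the other two groups.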